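The source may report more compounds than this note shows. Statements on the series, on what has been measured and on what is new or still open speak of the compounds shown alone.

Measured so far:
compound 1 `CNC(=O)c1cc(C(=O)N[C@H]2CC[C@H](O)CC2)n([C@@H](C)c2cccc(Cl)c2)n1` — 3.7
compound 2 `CNC(=O)c1cc(C(=O)N[C@H]2CC[C@H](O)CC2)n([C@@H](C)c2ccccc2)n1` — 2.9
compound 3 `CNC(=O)c1cc(C(=O)NCCO)n([C@@H](C)c2ccccc2)n1` — 2.4

In a physicochemical assay for lipophilicity (on this read-out higher numbers stand for higher lipophilicity and lower numbers for lower lipophilicity), compound 2 stands second highest of the three numbers: compound 1 lies above it and compound 3 below it, both gaps beyond the scatter. The next compound is compound 4 `CNC(=O)c1cc(C(=O)N[C@H]2CC[C@H](O)CC2)n([C@@H](C)c2cccc(C)c2)n1`, which differs from compound 2 in one place: methyl in place of hydrogen on an aromatic carbon. Among the measured compounds shown here, of the two measured steps, only one touches the same ring. Hydrogen in place of chloro on an aromatic carbon gave a number 0.80 log units lower from compound 1 to compound 2 (beyond the scatter), so putting a substituent on that ring moved the number clearly. The other step, 2-hydroxyethyl in place of 4-hydroxycyclohexyl on an amide-type nitrogen, gave a number 0.50 log units lower from compound 2 to compound 3 (beyond the scatter) and concerns a different part of the shared core, so it does not bear here. For the measured compounds named here, a methyl entering where a chloro once raised the number is expected to raise it too, though the chloro step is the only guide and a methyl need not match it. Compound 4 is therefore expected to show a number 0.50 log units higher from compound 2 to compound 4 (beyond the scatter). The estimate for compound 4 is 3.4, with a range from 3.1 to 3.7.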

Compound 4, distribution coefficient: 3.4
For compound 4 middle estimate and measured number coincide at the digits printed, and the stated range covers the measured number.
By their numbers in this assay, from the lowest: compound 3; then compound 2; then compounds 4 and 1 (each within the scatter of the next).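

In this assay, putting methyl in place of hydrogen on this aromatic carbon gives a number 0.50 log units higher from compound 2 to compound 4 (beyond the scatter), so chloro is no longer the only group shown at this position to stand clearly above hydrogen. The two substituents cannot be told apart on this read-out, since the step of a number 0.30 log units lower from compound 1 to compound 4 (within the scatter) stays within the scatter. Nothing available here explains why methyl and chloro give such similar numbers.

Going by these compounds, two substituents make only a short series, so it remains open whether a methoxy group, a nitrile or an amine on the same aromatic carbon would also stand above hydrogen. On these data alone, it is also open whether methyl would bring a step of similar size when the 2-hydroxyethyl group of compound 3 replaces the 4-hydroxycyclohexyl group on the amide-type nitrogen.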